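Adding trifluoromethoxy to compound 2: an expected step

The source may report more compounds than this note shows. Statements on the series, on what has been measured and on what is new or still open speak of the compounds shown alone.

Compound 2, `O=C(COc1ccc2c(=O)ccoc2c1)Nc1cccc(NC(=O)c2ccccc2)c1`, gives 120 nM in an assay on isolated protein for inhibition of Rho-associated protein kinase 1 (Homo sapiens), read by scintillation counting, radiometric assay and 33P incorporation, with a stated time of 40 min, in the presence of a further agent that is not named here; on this read-out higher numbers stand for weaker inhibition and lower numbers for stronger inhibition.
Compound 1, `COc1ccc(OCC(=O)Nc2cccc(NC(=O)c3ccc(N(C)C)cc3)c2)cc1OC`, gives > 10000 nM in this assay.

For the measured compounds named here, compound 2 is the only compound here with a number rather than a limit, so it is the sole point of reference. For compound 1 the value is a limit of the assay and not a number, as the limit of > 10000 nM in this assay, at which 1 of the 2 values shown sits, records. Compound 3, `O=C(COc1ccc2c(=O)ccoc2c1)Nc1cccc(NC(=O)c2ccc(OC(F)(F)F)cc2)c1`, has not yet been measured; it differs from compound 2 in one place: trifluoromethoxy in place of hydrogen on an aromatic carbon. Going by the values given here, no step between two measured compounds is available, so there is no measured guide to the size of this change. The change is expected to be small, with no clear direction beyond the usual scatter, and the expected step is a 1.3-fold higher number from compound 2 to compound 3 (0.10 log units; within the scatter). Compound 3 is therefore estimated at 150 nM, with a range from 40 nM to 600 nM.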

Compound 3, half-maximal inhibitory concentration: 869 nM
The estimate for compound 3 lay 5.8-fold (0.76 log units) below the measured number, and the stated range ends below it.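

The change from phenyl to 4-(trifluoromethoxy)phenyl now has a measured size in this assay, with a 7.2-fold higher number from compound 2 to compound 3 (0.86 log units; beyond the scatter) on an aromatic carbon para to a large group, so this position does not tolerate every group equally. The step lies beyond the usual scatter and runs toward weaker inhibition, yet compound 3 still gives a number, 869 nM, and not a limit of the assay. Nothing measured here accounts for the size of this step, which rests on a single pair of compounds.

On these data alone, it remains open whether fluorine, a methoxy group or an amine on this same carbon would give a number closer to that of compound 2. Also open, as far as these compounds go, is whether trifluoromethoxy would give a step of similar size on a core other than that of compound 2.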